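The source may report more compounds than this note shows. Statements on the series, on what has been measured and on what is new or still open speak of the compounds shown alone.

Measured compounds in this series:

compound 1 `C[C@H]1[C@H](NCc2cncs2)C[C@H]2C[C@@H]1C2(C)C`: > 100000 nM
compound 2 `CCc1csc(CN[C@@H]2C[C@H]3C[C@@H]([C@H]2C)C3(C)C)c1`: 25000 nM
compound 3 `C[C@H]1[C@H](NCc2sccc2-c2ccccc2)C[C@H]2C[C@@H]1C2(C)C`: 12500 nM

All values come from an ADME assay on MDCK cells (Canis lupus familiaris) for cytotoxicity, read by microscopy, with a stated time of 48 h; a higher number here means that more compound is tolerated, a lower number that less compound is tolerated. Compound 1 stands at the limit of > 100000 nM in this assay, at which 1 of the 3 values shown sits, which is a limit of this assay and not a number. Compound 2 and compound 3 give numbered values in this assay, both lying under that limit.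

Compound 4 `C[C@H]1[C@H](NCc2ccsc2)C[C@H]2C[C@@H]1C2(C)C` is not yet measured. It differs from compound 1 by thiophen-3-yl in place of 1,3-thiazol-5-yl on a saturated chain carbon bound to an amine nitrogen. Among the measured compounds shown here, no measured pair in the set shares exactly this change, so the size of the step is open. Compound 4 is expected to fall short of the limit reached by compound 1. Compound 4 is expected to show a step of an at least 2.0-fold lower number from compound 1 to compound 4 (0.30 log units; that floor lies within the scatter) toward less tolerated compound, because the thiophene-bearing compound 2 gives 25000 nM. Compound 4 is estimated at 50000 nM, within 20000 nM to 100000 nM.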

Compound 4, minimum cytotoxic concentration: 50000 nM
Estimate against measurement, compound 4: no gap at the digits printed; the range from low to high includes it.
By their numbers in this assay, from the lowest: compounds 3, 2 and 4 (each within the scatter of the next, the first and the last beyond it). At a limit, above all of these: compound 1.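

In this assay the change to thiophen-3-yl in place of 1,3-thiazol-5-yl on a saturated chain carbon bound to an amine nitrogen gives an at least 2.0-fold lower number from compound 1 to compound 4 (0.30 log units; that floor lies within the scatter). Among the compounds shown here, this is the first single-place step, and it puts a numbered value on an unsubstituted thiophen-3-yl on the core of compound 1. Compound 1 remains a limit and not a number, so only a floor of the step can be read: the limit of > 100000 nM in this assay, at which 1 of the 4 values shown sits.

Going by these compounds, the full size of the step stays open. Also open, on these data alone, is where furan-3-yl or pyridin-3-yl would stand at this place.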